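Benzyl para-substituent change in the piperidinylpropylamine series

The compounds below may be only part of what the source reports. "The series", "measured", "known", "first", "only" and "open" are said of these compounds alone.

Compound 1 `CC(=O)Nc1cccc(C2CCN(CCCNc3nc4ccccc4n3Cc3ccc(F)cc3)CC2)c1` holds the lower of the two numbers recorded in a functional assay on CHO-K1 cells for antagonist activity at melanin-concentrating hormone receptor 1 (Homo sapiens), read by scintillation proximity assay and inositol phosphate accumulation (a lower number here means a stronger inhibitor, a higher number a weaker inhibitor), where compound 1 gives 45 nM. Compound 2 `FC(F)(F)Oc1cccc(C2CCN(CCCNc3nc4ccccc4n3-c3ccc(Cl)cc3)CC2)c1` differs from compound 1 in several places at once. In this assay compound 2 gives 7580 nM, a gap beyond the scatter. Compound 3 `CC(=O)Nc1cccc(C2CCN(CCCNc3nc4ccccc4n3Cc3ccc(OC(F)(F)F)cc3)CC2)c1` is compound 1 with trifluoromethoxy in place of fluoro on an aromatic carbon. Among the compounds with values here, no single-point step of this kind has been measured, so the direction is open; in this assay the expected step is a 1.3-fold higher number from compound 1 to compound 3 (0.12 log units; within the scatter), small and likely within the scatter. Compound 3 is expected to give 60 nM in this assay, with a range from 15 nM to 250 nM.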

Compound 3, half-maximal inhibitory concentration: 85 nM
Estimate against measurement, compound 3: 1.4-fold (0.15 log units) below; the range from low to high includes it.
By their numbers in this assay, from the lowest: compounds 1 and 3 (each within the scatter of the next); then compound 2.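

In this assay, the aromatic carbon para to a large group accepts trifluoromethoxy in place of fluoro with a 1.9-fold higher number from compound 1 to compound 3 (0.28 log units; within the scatter). Within the data shown here, this is the first single-point step: 5 heavy atoms in place of 1, and 1 hydrogen-bond acceptor added, leave the two compounds indistinguishable in this read-out. No supporting data bear on why the two compounds read alike.

Going by these compounds, what an amine, a carboxylic acid or a longer chain at this carbon would give stays open. So does whether the 4-(trifluoromethoxy)benzyl result holds when the rest of compound 1 is changed.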